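The source may report more compounds than this note shows. Statements on the series, on what has been measured and on what is new or still open speak of the compounds shown alone.

Among the measured compounds shown here, compound 2 `C=C(Br)C(=O)Nc1ccc(C(=O)/C=C/c2cccc(OC)c2)cc1` is one of two compounds measured so far in an ADME assay on CCRF-CEM cells (Homo sapiens) for antiproliferative activity, with a stated time of 48 h; a lower number here means a stronger inhibitor, a higher number a weaker inhibitor. In this assay compound 2 gives 1800 nM, the larger of the two numbers, though its gap to the other lies within the scatter of repeated measurements. Compound 1 `C=C(Br)C(=O)Nc1ccc(C(=O)/C=C/c2ccc(OC)cc2)cc1` differs only in where its methoxy group sits, and in this assay compound 1 gives 1100 nM; the step of a 1.6-fold higher number from compound 1 to compound 2 (0.21 log units; within the scatter) is therefore too small to count as a real change.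

Compound 3 `C=C(Br)C(=O)Nc1ccc(C(=O)/C=C/c2cc(OC)cc(OC)c2)cc1` is not yet measured. Relative to compound 2 the change is methoxy in place of hydrogen on an aromatic carbon. For the measured compounds named here, the only measured step concerns moving a single methoxy group, not adding a second one, so it bears on this change only loosely, and it was itself within the scatter. Compound 3 is accordingly expected to show a step of no change at the digits printed from compound 2 to compound 3 (within the scatter) that stays within the scatter. The estimate for compound 3 is 1800 nM, with a range from 700 nM to 4500 nM.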

Compound 3, half-maximal inhibitory concentration: 2200 nM
Compound 3: the middle estimate sits 1.2-fold (0.09 log units) below what was measured; the measured number falls inside the stated range.
By their numbers in this assay, from the lowest: compounds 1, 2 and 3 (each within the scatter of the next).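

In this assay, putting a second methoxy group on a carbon meta to the existing methoxy group gives a 1.2-fold higher number from compound 2 to compound 3 (0.09 log units; within the scatter) and so shows no change that can be told apart from the scatter. The earlier step showed this only for moving a single methoxy group, whereas this one shows that the ring can also carry an added methoxy group, with its 2 heavy atoms and 1 hydrogen-bond acceptor, without a readable shift in the number. Nothing measured here explains this result.

As far as these compounds go, because only methoxy groups have been compared on this ring, it remains open whether an amine, a carboxylic acid or a longer alkoxy chain on the same carbon would produce a step beyond the scatter. From the compounds shown here alone, the contribution of the parts of the core shared by all three compounds also remains open.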